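A few compounds are considered here, and "the series" means these few. Any claim that something is new, unique, unknown or untested is made for them only; others in the source may bear on it.

Of the compounds shown here, three that share one core have been measured in a functional assay on PC-3 cells (Homo sapiens) for inhibition, read by sulforhodamine B assay, with a stated time of 48 h; a higher number here means a weaker inhibitor of growth, a lower number a stronger inhibitor of growth. Compound 1 `CCOC(=O)C1=C(C)NC(=O)NC1c1ccc(SC)cc1` gives 9.5 ug/mL in this assay, compound 3 `CCOC(=O)C1=C(C)NC(=S)NC1c1cccc(OC)c1` gives 10.2 ug/mL, and compound 2 `CCOC(=O)C1=C(C)NC(=S)NC1c1ccc(O)cc1` gives 47.6 ug/mL. Compound 2 therefore stands with the highest number of the three, which means the weakest growth inhibition; its distance from compound 3 and from compound 1 lies beyond the usual scatter in both cases, with compound 3 the nearer of the two. Compound 4 `CCOC(=O)C1=C(C)NC(=S)NC1c1ccc(SC)cc1` has not yet been measured. It differs from compound 2 in one place: methylsulfanyl in place of hydroxy on an aromatic carbon. For the measured compounds named here, no pair of measured compounds differs in only that one place, so the size of this step cannot be read directly from the measurements. Two hints are available. Compound 1 carries the same methylsulfanyl group and gives 9.5 ug/mL, and compound 3, which carries neither a hydroxy nor a methylsulfanyl group, gives 10.2 ug/mL. Both sit well below compound 2. On that basis a move toward stronger growth inhibition, larger than the scatter, is expected. The estimate for compound 4 is 12 ug/mL, with a range from 5 ug/mL to 30 ug/mL. This estimate means that a step of a 4.0-fold lower number from compound 2 to compound 4 (0.60 log units; beyond the scatter) is expected.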

Compound 4, concentration for 50% growth inhibition: 23.6 ug/mL
Beside the measured number, compound 4's estimate is 2.0-fold (0.29 log units) below it; low and high end bracket the measured number.
By their numbers in this assay, from the lowest: compounds 1 and 3 (each within the scatter of the next); then compounds 4 and 2 (each within the scatter of the next).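

In this assay, the exchange of hydroxy for methylsulfanyl on an aromatic carbon, para to a large group, can now be read directly within a single pair of compounds (a 2.0-fold lower number from compound 2 to compound 4 (0.30 log units; within the scatter)). For the compounds shown here, the earlier compounds offered only indirect hints, whereas this pair isolates the one change, and its step does not go beyond the scatter. A group with a hydrogen-bond donor thus gives way to a group without one, and this pair shows no clear gain or loss in growth inhibition; nothing available explains why the two numbers lie so close.

Going by these compounds, this is a single pair on a single core, so whether the same exchange would also stay within the scatter on the core of compound 1 remains open. Also open, on these data alone, is how this position would respond to quite different groups, such as an amine, a carboxylic acid or a longer chain in place of methylsulfanyl, since neither hydroxy nor methylsulfanyl says anything about those.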